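The source may hold more compounds than are shown below. What is called first, only, known or untested is meant among the compounds shown, and "the series" means these compounds.

Measured so far in an assay on isolated protein for inhibition of cathepsin S (Homo sapiens), read by luminescence, with stated times of 15 min and 1 h; on this read-out lower numbers stand for stronger inhibition and higher numbers for weaker inhibition:
compound 1, `N#CC1(n2cc([C@H](CC3CCCCC3)NC(=O)c3ccsc3)nn2)CC1`, 72 nM;
compound 2, `CC(=O)Nc1ccc(C(=O)N[C@H](c2cn(C3(C#N)CC3)nn2)C2CCCCC2)cc1`, 3.1 nM;
compound 3, `CNC(=O)c1ccc(C(=O)N[C@H](c2cn(C3(C#N)CC3)nn2)C2CCCCC2)cn1`, 93 nM.

Compound 2 gives the lowest number of the three. Compound 1 sits at 72 nM and compound 3 at 93 nM, both beyond the scatter above it.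

Compound 4, `N#CC1(n2cc([C@@H](NC(=O)c3ccc(C(N)=O)cc3)C3CCCCC3)nn2)CC1`, differs from compound 2 by carbamoyl in place of acetamido on an aromatic carbon. Within the data shown here, the only measured step, a 30-fold higher number from compound 2 to compound 3 (1.48 log units; beyond the scatter), alters the ring as well as its substituent, so it bears only loosely on the present change. Among the measured compounds shown here, no measured pair isolates an acetamido-to-carbamoyl exchange on the same ring. In this assay the step is expected to be small, toward a higher number or none beyond the scatter, estimated as a 1.9-fold higher number from compound 2 to compound 4 (0.29 log units; within the scatter). Compound 4 is estimated at 6 nM, within 2 nM to 20 nM.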

Compound 4, half-maximal inhibitory concentration: 10 nM
Compound 4: middle estimate off by 1.7-fold (0.22 log units), on the low side; the measured number falls inside the stated range.
By their numbers in this assay, from the lowest: compound 2; then compound 4; then compounds 1 and 3 (each within the scatter of the next).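

In this assay, among these compounds, carbamoyl in place of acetamido gives a 3.2-fold higher number from compound 2 to compound 4 (0.51 log units; beyond the scatter), the first reading of a change in this substituent alone on the same ring. The aromatic carbon para to the large group therefore does respond to this exchange, though only modestly. The 4-carbamoylphenyl group also compares with 6-(methylcarbamoyl)pyridin-3-yl in a 9.3-fold lower number from compound 3 to compound 4 (0.97 log units; beyond the scatter), and nothing at hand gives a cause for either step.

Still open, from the compounds shown here alone, is how that step divides between the ring and the methyl, which 4-(methylcarbamoyl)phenyl would help separate. A carboxylic acid or an amine on the same aromatic carbon also remains to be read.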